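Isobutyl Replaced by Difluorophenyl in a Bombesin Receptor Agonist Series

The source may report more compounds than this note shows. Statements on the series, on what has been measured and on what is new or still open speak of the compounds shown alone.

Compound 3 `CC(C)CCc1cnc(CCc2ccc(-c3ccccc3C(=O)O)cc2)[nH]1` gives the lowest of the three numbers in an in vitro functional assay on cells for agonist activity at Bombesin receptor subtype-3 (Homo sapiens), read by luminescence and calcium flux (a higher number here means that more compound is needed for the effect, a lower number that less compound is needed), namely 119 nM. Compound 1 `O=C(O)c1ccccc1-c1ccc(CCc2ncc(CC3CCCC3)[nH]2)cc1` gives 133 nM, and compound 2 `CCCCc1cnc(CCc2ccc(-c3ccccc3C(=O)O)cc2)[nH]1` gives 2710 nM; the steps are a 1.1-fold lower number from compound 1 to compound 3 (0.05 log units; within the scatter) and a 23-fold lower number from compound 2 to compound 3 (1.36 log units; beyond the scatter). Compound 4 `O=C(O)c1ccccc1-c1ccc(CCc2ncc(Cc3cccc(F)c3F)[nH]2)cc1` carries 2,3-difluorophenyl in place of isobutyl on a saturated chain carbon bound to an aromatic carbon. At this same place the measured steps show a 20-fold higher number from compound 1 to compound 2 (1.31 log units; beyond the scatter), while the cyclopentyl and isobutyl analogues, compound 1 and compound 3, sit within the scatter of one another. No aromatic ring at this position has been measured, so the step from compound 3 to compound 4 is expected to be small, most likely a 1.3-fold higher number from compound 3 to compound 4 (0.13 log units; within the scatter), with no clear direction. Compound 4 is therefore estimated at 160 nM in this assay, within a range of 40 nM to 650 nM.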

Compound 4, half-maximal effective concentration: 87 nM
Compound 4: the middle estimate sits 1.8-fold (0.26 log units) above what was measured; measured number inside the range.
By their numbers in this assay, from the lowest: compounds 4, 3 and 1 (each within the scatter of the next); then compound 2.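

The place on a saturated chain carbon bound to an aromatic carbon accepts an aromatic ring: in this assay the 2,3-difluorophenyl of compound 4 stays within the scatter of both the isobutyl and the cyclopentyl group (a 1.4-fold lower number from compound 3 to compound 4 (0.14 log units; within the scatter); a 1.5-fold lower number from compound 1 to compound 4 (0.18 log units; within the scatter)). Against propyl the change is large (a 31-fold lower number from compound 2 to compound 4 (1.49 log units; beyond the scatter)), so among these four compounds the high number stays with compound 2 alone. Nothing measured here explains this. As far as these compounds go, what the two fluorines contribute stays open, as an unsubstituted phenyl group would be needed to tell. From the compounds shown here alone, the effect of a pyridine ring or an amine at this place also remains open.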